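This account rests on a few compounds, and the source may have more. Where it says the series, first, only, none or still open, it means among the compounds named here.

Series notes. Compound 1 `C=C(Br)C(=O)Nc1cccc(-c2cn3nc(-c4ccc(OCC)cc4)sc3n2)c1` and compound 2 `C=C(Br)C(=O)Nc1cccc(-c2cn3c(-c4ccccc4)csc3n2)c1` share the common core and the amide; they differ in the arrangement of the substituents on the fused system. In a functional assay on HeLa cells (Homo sapiens) for inhibition, read by cell counting, with a stated time of 4 days (on this read-out higher numbers stand for weaker inhibition and lower numbers for stronger inhibition), compound 1 gives 1100 nM, and compound 2 gives 3400 nM. Compound 1 thus holds the lower of the two numbers, and its gap to compound 2 lies beyond the usual scatter. Among the compounds with values here, no single-site step between measured compounds is available, so the size of any one change has no precedent within this set.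

Compound 3 `C=C(Br)C(=O)Nc1cccc(-c2cn3nc(CCc4ccccc4)sc3n2)c1` is the next member. Relative to compound 1 it carries phenethyl in place of 4-ethoxyphenyl on an aromatic carbon. The aromatic ring attached at that position in compound 1 gives way to a chain-borne ring, and the single acceptor is lost. In this assay the expected change is a 2.4-fold higher number from compound 1 to compound 3 (0.37 log units; beyond the scatter), toward weaker inhibition and probably beyond the scatter. For compound 3 the estimate in this assay is 2600 nM, with a range from 900 nM to 7500 nM.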

Compound 3, half-maximal inhibitory concentration: 3300 nM
Compound 3: the middle estimate sits 1.3-fold (0.10 log units) below what was measured, and the stated range covers the measured number.
By their numbers in this assay, from the lowest: compound 1; then compounds 3 and 2 (each within the scatter of the next).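

In this assay this position gives the series its first single-site step (a 3.0-fold higher number from compound 1 to compound 3 (0.48 log units; beyond the scatter)): on an aromatic carbon next to the ring nitrogen and next to the ring sulfur, phenethyl in place of 4-ethoxyphenyl goes toward weaker inhibition, and the size of the change is modest. The step bundles two differences, since the ring moves from direct attachment onto a chain and the ethoxy oxygen leaves, so this pair cannot assign the change to either one. No measurement at hand bears on why the number moves.

Still open, as far as these compounds go, is which of the two differences carries the step: a plain phenyl or a 4-ethylphenyl at this carbon would separate them. From the compounds shown here alone, how a longer chain or a terminal amine would read at this position also remains unknown.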